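Removing the Methyl from the Fluorinated Sulfonyl Aryl

The compounds below may be only part of what the source reports. "The series", "measured", "known", "first", "only" and "open" are said of these compounds alone.

Compound 3 `Cc1ccc2ncc(S(=O)(=O)c3ccc(C)c(F)c3)c(N3CCC(C)CC3)c2c1` stands highest of the three measured compounds in an assay on isolated protein for displacement of a labelled ligand from metabotropic glutamate receptor 5 (Homo sapiens), with a stated time of 60 min, tested at 1 uM (on this read-out higher numbers stand for more inhibition at the one concentration tested (going by the name of the read-out) and lower numbers for less inhibition), giving 91%. Compound 2 `Cc1ccc2ncc(S(=O)(=O)c3cc(Cl)cc(Cl)c3)c(N3CCC(C)CC3)c2c1` gives 75% and compound 1 `Cc1ccc2ncc(S(=O)(=O)c3ccc(C#N)cc3)c(N3CCC(C)CC3)c2c1` gives 55%; the step of a number 36 percentage points higher from compound 1 to compound 3 (beyond the scatter) is the largest seen, while a number 16 percentage points higher from compound 2 to compound 3 (beyond the scatter) and a number 20 percentage points higher from compound 1 to compound 2 (beyond the scatter) are smaller. Compound 4 `Cc1ccc2ncc(S(=O)(=O)c3cccc(F)c3)c(N3CCC(C)CC3)c2c1` differs from compound 3 by hydrogen in place of methyl on an aromatic carbon. Going by the values given here, no measured step removes a single methyl: every step so far swaps the entire aryl group on the sulfonyl sulfur, and those swaps moved this assay by modest to large amounts. Losing one carbon is expected to matter less than a whole-ring swap, so compound 4 is expected to drop by a number 15 percentage points lower from compound 3 to compound 4 (beyond the scatter). Compound 4 is therefore estimated at 76%, with a range from 56% to 92%.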

Compound 4, a percentage reported as inhibition, at one concentration (the size of the read-out at that concentration, not a potency): 94%
Beside the measured number, compound 4's estimate is 18 percentage points below it; the whole stated range lies below it.
By their numbers in this assay, from the lowest: compound 1; then compound 2; then compounds 3 and 4 (each within the scatter of the next).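

Hydrogen in place of methyl, ortho to a fluoro group, gives a number 3 percentage points higher from compound 3 to compound 4 (within the scatter) in this assay and so the methyl is not needed for this level of inhibition. The 3-fluorophenyl group holds the same lead as the 3-fluoro-4-methylphenyl group over the other aryl groups, with a number 19 percentage points higher from compound 2 to compound 4 (beyond the scatter) and a number 39 percentage points higher from compound 1 to compound 4 (beyond the scatter) on the sulfonyl sulfur. Nothing available explains why the methyl can go.

As far as these compounds go, whether hydrogen can also replace the fluoro group stays open. So does what a methoxy group or an amine would do at the carbon the methyl left.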